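Nitrofuran sulfonamide series: ring exchange on the sulfonyl sulfur

A few compounds are considered here, and "the series" means these few. Any claim that something is new, unique, unknown or untested is made for them only; others in the source may bear on it.

Measured so far in an assay on CHO-K1 cells for activation of DNA damage-inducible transcript 3 protein (Homo sapiens), read by a luciferase reporter; on this read-out lower numbers stand for an effect already at smaller amounts and higher numbers for an effect only at larger amounts of compound:
compound 1 `O=C(Nc1ccc(S(=O)(=O)N2CCC(F)CC2)cc1)c1ccc([N+](=O)[O-])o1` — 600 nM
compound 2 `CC1CCN(S(=O)(=O)c2ccc(NC(=O)c3ccc([N+](=O)[O-])o3)cc2)CC1` — 700 nM
compound 3 `O=C(Nc1ccc(S(=O)(=O)C2CCOCC2)cc1)c1ccc([N+](=O)[O-])o1` — 1200 nM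

Compound 1 gives the lowest of the three numbers in this assay, but the other two sit close to it: the step of a 1.2-fold higher number from compound 1 to compound 2 (0.07 log units; within the scatter) and the step of a 2.0-fold higher number from compound 1 to compound 3 (0.30 log units; within the scatter) both fall within the scatter, as does a 1.7-fold higher number from compound 2 to compound 3 (0.23 log units; within the scatter). Within these three compounds, no exchange at the sulfonyl sulfur has shifted the read-out further than repeat measurements would.

Compound 4 `O=C(Nc1ccc(S(=O)(=O)C2CCCCC2)cc1)c1ccc([N+](=O)[O-])o1` has not yet been measured. It differs from compound 1 at a single place: cyclohexyl in place of 4-fluoropiperidin-1-yl on a sulfonyl sulfur. The measured step that bears most directly on this is a 2.0-fold higher number from compound 1 to compound 3 (0.30 log units; within the scatter), where the same 4-fluoropiperidin-1-yl left the sulfonyl sulfur; the related step of a 1.7-fold higher number from compound 2 to compound 3 (0.23 log units; within the scatter) points the same way and was also small. For compound 4 a step of comparable size, a 1.5-fold higher number from compound 1 to compound 4 (0.18 log units; within the scatter), is expected, and the three measurements give no ground to expect a move beyond the scatter in either direction. Compound 4 is therefore estimated at 900 nM in this assay, with a range from 400 nM to 2000 nM.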

Compound 4, concentration for half-maximal activity: 700 nM
Estimate against measurement, compound 4: 1.3-fold (0.11 log units) above; the measured number falls inside the stated range.
By their numbers in this assay, from the lowest: compounds 1, 2, 4 and 3 (each within the scatter of the next).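

Compound 4 is the only one of the four whose ring on the sulfonyl sulfur is of carbon only, and in this assay this ring gives a 1.2-fold higher number from compound 1 to compound 4 (0.07 log units; within the scatter) when it stands in place of 4-fluoropiperidin-1-yl and no change at the digits printed from compound 2 to compound 4 (within the scatter) when it stands in place of 4-methylpiperidin-1-yl. Against oxan-4-yl, the exchange gives a 1.7-fold lower number from compound 3 to compound 4 (0.23 log units; within the scatter) and so, among these four compounds, a hetero atom in the six-membered ring is not needed for a read-out in this range, and no exchange at this place has yet gone beyond the scatter. No measurement at hand accounts for how small these steps are.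

As far as these compounds go, all four compounds carry a six-membered non-aromatic ring on the sulfonyl sulfur, so it stays open whether a charged amine such as a piperazine, a carboxylic acid on the ring, a phenyl ring or a longer open chain at this place would move the number beyond the scatter. The rest of the shared core is the same throughout, so these compounds also say nothing about the nitro group or the amide.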